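The compounds below may be only part of what the source reports. "The series", "measured", "known", "first", "only" and "open" are said of these compounds alone.

In a physicochemical assay for lipophilicity, read by HPLC, at pH 7.4 (a lower number here means a more polar compound, a higher number a more lipophilic compound), two compounds have been measured so far.

- compound 1 `O=C(O)CCn1c(=O)oc2cc(OCC3CCC3)c(Cl)cc21` gives 2.9
- compound 2 `CCc1cc2oc(=O)n(CCC(=O)O)c2cc1Cl` gives 1.94

Compound 2 holds the lower of the two numbers, its gap to compound 1 lying beyond the scatter. The next compound to be measured is compound 3 `O=C(O)CCn1c(=O)oc2cc(Cl)c(Cl)cc21`, which carries chloro in place of ethyl on an aromatic carbon, ortho to a chloro group: chloro in place of ethyl on an aromatic carbon. For the measured compounds named here, only one measured step bears on this change, a number 0.96 log units lower from compound 1 to compound 2 (beyond the scatter), which was modest but beyond the scatter. That step replaced cyclobutylmethoxy, a much larger group than the ethyl that leaves here, so a smaller step is expected in this assay, slightly downward and probably within the scatter. The expected change is a number 0.14 log units lower from compound 2 to compound 3 (within the scatter). The estimate for compound 3 is 1.8, with an expected range from 1.4 to 2.2.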

Compound 3, distribution coefficient: 1.61
For compound 3 the middle estimate is 0.19 log units above the measured one, within the range that was stated.
By their numbers in this assay, from the lowest: compound 3; then compound 2; then compound 1.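

In this assay this position, on the aromatic carbon ortho to a chloro group, can now be read across three groups: exchanging ethyl for chloro gives a number 0.33 log units lower from compound 2 to compound 3 (beyond the scatter) and so moves the number past the scatter even though the two groups are both small. Exchanging cyclobutylmethoxy for chloro gives a number 1.29 log units lower from compound 1 to compound 3 (beyond the scatter) and is the largest step seen, leaving chloro with the lowest number, then ethyl, then cyclobutylmethoxy. No measurement at hand explains this order.

The compounds leave open where an amine, a hydroxyl group or a longer alkyl chain at this position would fall in this assay. They also leave open whether the same order would hold if an amide took the place of the carboxylic acid.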